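Ethoxycarbonyl in place of methyl: compound 3 to compound 4

The compounds below may be only part of what the source reports. "The series", "measured", "known", "first", "only" and "open" are said of these compounds alone.

Within the data shown here, in a functional assay on HCT-116 cells (Homo sapiens) for antiproliferative activity, read by MTT assay, with a stated time of 72 h (a lower number here means a stronger inhibitor, a higher number a weaker inhibitor), compound 1 `C=CC(=O)Nc1nc(-c2ccccc2)cs1` gives 18600 nM and compound 3 `C=CC(=O)Nc1nc(-c2ccccc2)c(C)s1` gives 20100 nM, so compound 3 stands within the scatter of the only other exact number. Compound 2 `C=CC(=O)Nc1scc(-c2ccccc2)c1C(=O)OCC` also bears ethoxycarbonyl, on a core of its own, and gives > 30000 nM, a limit of the assay, which tilts the expectation toward a higher number.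

Compound 4 `C=CC(=O)Nc1nc(-c2ccccc2)c(C(=O)OCC)s1` differs from compound 3 by ethoxycarbonyl in place of methyl on an aromatic carbon, next to the ring sulfur. Among the measured compounds shown here, the one measured step at this place, a 1.1-fold higher number from compound 1 to compound 3 (0.03 log units; within the scatter), is a much smaller replacement and gives no sign of sensitivity there, but it does not test a group of this size. A small move toward a higher number in this assay is therefore expected, and the estimated step is a 1.3-fold higher number from compound 3 to compound 4 (0.13 log units; within the scatter). For compound 4 the estimated value is 27000 nM, with an expected range of 12000 nM to 60000 nM.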

Compound 4, half-maximal inhibitory concentration: 19600 nM
Compound 4: the middle estimate sits 1.4-fold (0.14 log units) above what was measured; the measured number falls inside the stated range.
By their numbers in this assay, from the lowest: compounds 1, 4 and 3 (each within the scatter of the next). At a limit, above all of these: compound 2.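

In this assay this aromatic carbon next to the ring sulfur now carries a much larger group than methyl, and the exchange for ethoxycarbonyl leaves the number within the scatter (a 1.0-fold lower number from compound 3 to compound 4 (0.01 log units; within the scatter)). Measured against hydrogen on the same core, ethoxycarbonyl also stays within the scatter (a 1.1-fold higher number from compound 1 to compound 4 (0.02 log units; within the scatter)), so hydrogen, methyl and ethoxycarbonyl at this place cannot be told apart in this read-out. No measurement shown gives a reason for this flat result.

Going by these compounds, whether an amine, a carboxylic acid or a longer ester chain at this aromatic carbon would also stay within the scatter remains open. On these data alone, it also remains open whether any replacement here can move the number beyond the scatter in either direction.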